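The source may report more compounds than this note shows. Statements on the series, on what has been measured and on what is new or still open speak of the compounds shown alone.

Measured so far in a functional assay on HEK293 cells for antagonist activity at transient receptor potential cation channel subfamily V member 1 (Homo sapiens), read by calcium flux; on this read-out higher numbers stand for weaker inhibition and lower numbers for stronger inhibition:

Compound 1 `CN(c1nc2c(Nc3ccc(C(F)(F)F)cc3)ncnc2s1)c1c(Cl)cccc1Cl`: 502 nM
Compound 2 `CSc1ccccc1Nc1nc2c(Nc3ccc(C(F)(F)F)cc3)ncnc2s1`: 43 nM
Compound 3 `FC(F)(F)c1ccc(Nc2ncnc3sc(Nc4c(Cl)cccc4Cl)nc23)cc1Cl`: 21 nM

Compound 2 sits between the other two on these numbers: compound 1 gives a higher number, compound 3 a lower one, and both gaps are beyond the usual scatter. Among the compounds with values here, the one step that can be isolated is a 12-fold lower number from compound 1 to compound 2 (1.07 log units; beyond the scatter), where (2-(methylsulfanyl)phenyl)amino replaces (2,6-dichlorophenyl)(methyl)amino on an aromatic carbon.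

Compound 4 `OCc1cc(Cl)c(Nc2nc3c(Nc4ccc(C(F)(F)F)cc4)ncnc3s2)c(Cl)c1` has not yet been measured. Compared with compound 2, the change is 2,6-dichloro-4-(hydroxymethyl)phenyl in place of 2-(methylsulfanyl)phenyl on a nitrogen on an aromatic ring, in words 2,6-dichloro-4-(hydroxymethyl)phenyl in place of 2-(methylsulfanyl)phenyl on a nitrogen on an aromatic ring. Within the data shown here, no measured step covers exactly this exchange. Compound 3 carries the 2,6-dichlorophenyl ring on this nitrogen, though it also differs from compound 2 elsewhere. The value of compound 3, 21 nM, shows that such a ring is compatible with a low number. Compound 1, with its higher number, adds a methyl on that nitrogen, so it does not speak to the change here.

A modest step in this assay is therefore expected, leaning toward a lower number: compound 4 is estimated at 30 nM, within 8 nM to 120 nM, which would be a step of a 1.4-fold lower number from compound 2 to compound 4 (0.16 log units; within the scatter).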

Compound 4, half-maximal inhibitory concentration: 1 nM
Compound 4: the middle estimate sits 30-fold (1.48 log units) above what was measured, outside the stated range (below it).
By their numbers in this assay, from the lowest: compound 4; then compound 3; then compound 2; then compound 1.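

In this assay, the group on this nitrogen proves to be a strong lever on the number: a 43-fold lower number from compound 2 to compound 4 (1.63 log units; beyond the scatter) with 2,6-dichloro-4-(hydroxymethyl)phenyl in place of 2-(methylsulfanyl)phenyl. Within the data shown here, the one earlier step at this site also removed a methyl from the nitrogen, whereas here the nitrogen keeps its hydrogen on both sides and only the aromatic group changes, with the entering group bringing a hydrogen-bond donor that the leaving group lacks. No information is available to explain why this exchange has so large an effect.

Still open, on these data alone, is how much of the step belongs to the two chlorines, how much to the hydroxymethyl and how much to the loss of the methylsulfanyl: compound 3 has a dichlorophenyl group without the hydroxymethyl, but it also differs from compound 4 in a second place. Also open, as far as these compounds go, is whether an amine or a carboxylic acid in place of the hydroxymethyl, or a longer chain such as hydroxyethyl, would give a number as low as that of compound 4, 1 nM.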